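This account rests on a few compounds, and the source may have more. Where it says the series, first, only, none or still open, it means among the compounds named here.

Series notes, a functional assay on SW480 cells (Homo sapiens) for inhibition, read by luminescence and resazurin assay, with a stated time of 3 days; a lower number here means a stronger inhibitor, a higher number a weaker inhibitor. Measured so far: compound 1 `CNc1nc(NCc2ccc(NS(=O)(=O)c3ccc(F)cc3)cc2)c2ccccc2n1` gives 4800 nM; compound 2 `CNc1nc(NCc2ccc(NC(=O)c3ccc(F)cc3)cc2Cl)c2ccccc2n1` gives 2300 nM; compound 3 `CCNc1nc(NCc2ccc(NC(=O)c3ccc(F)cc3)cc2Cl)c2ccccc2n1` gives 1600 nM.

Compound 2 holds the second highest of the three numbers in this assay. Its nearest neighbour is compound 3, with a 1.4-fold lower number from compound 2 to compound 3 (0.16 log units; within the scatter), a change on the saturated chain carbon only. Compound 1 lies furthest from compound 2, a gap beyond the scatter, but the two structures differ in more than one place, so their values are simply taken as they stand.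

Compound 4 `CNc1nc(NCc2ccc(NC(=O)c3ccc(F)cc3)cc2)c2ccccc2n1` differs from compound 2 by hydrogen in place of chloro on an aromatic carbon. Among the measured compounds shown here, no measured step touches this aromatic carbon; the single measured step concerns a different part of the molecule and stays within the scatter. With nothing in the series to point either way, compound 4 is expected to give 3000 nM in this assay, within 1000 nM to 9000 nM. This estimate means a 1.3-fold higher number from compound 2 to compound 4 (0.12 log units; within the scatter), a step expected to stay within the scatter.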

Compound 4, half-maximal inhibitory concentration: 2000 nM
Beside the measured number, compound 4's estimate is 1.5-fold (0.18 log units) above it; the range from low to high includes it.
By their numbers in this assay, from the lowest: compounds 3, 4 and 2 (each within the scatter of the next); then compound 1.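

In this assay the chloro on this aromatic carbon can give way to hydrogen, with a 1.2-fold lower number from compound 2 to compound 4 (0.06 log units; within the scatter) as the size of that step. Among the compounds shown here, the swap on the nitrogen on the aromatic ring counts for more, with a 2.4-fold lower number from compound 1 to compound 4 (0.38 log units; beyond the scatter) after (4-fluorophenyl)carbonyl replaces (4-fluorophenyl)sulfonyl, and it is the only single-place step so far beyond the scatter. Nothing available explains either step.

Still open, on these data alone, is how a methoxy group, a fluoro or an amine would fare on this aromatic carbon. As far as these compounds go, it is also open whether the carbonyl-for-sulfonyl step holds with the chloro present.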